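This account rests on a few compounds, and the source may have more. Where it says the series, first, only, none or still open, it means among the compounds named here.

In an ADME assay on MT4 cells (Homo sapiens) for cytotoxicity, read by MTT assay, with a stated time of 5 days (on this read-out higher numbers stand for lower toxicity in this test and lower numbers for higher toxicity in this test), compound 1 `COc1cc2nc([S+]([O-])CC(=O)Nc3ccccc3[N+](=O)[O-])nc(Nc3c(Cl)cc(/C=C/C#N)cc3Cl)c2cc1OC` reports > 199000 nM, which is a limit of the assay. Compound 2 `COc1cc2nc([S+]([O-])CC(=O)Nc3ccc(Cl)cc3)nc(Nc3c(Cl)cc(/C=C/C#N)cc3Cl)c2cc1OC` gives 14400 nM. Among the compounds with values here, compound 3 `COc1cc2nc([S+]([O-])CC(=O)Nc3cccc(C(F)(F)F)c3)nc(Nc3c(Cl)cc(/C=C/C#N)cc3Cl)c2cc1OC` gives 21800 nM, level with the one other number. Compound 4 `COc1cc2nc([S+]([O-])CC(=O)Nc3ccc(C(F)(F)F)cc3)nc(Nc3c(Cl)cc(/C=C/C#N)cc3Cl)c2cc1OC` carries 4-(trifluoromethyl)phenyl in place of 3-(trifluoromethyl)phenyl on an amide-type nitrogen. The steps of an at least 13-fold lower number from compound 1 to compound 2 (1.14 log units; beyond the scatter) and an at least 9.1-fold lower number from compound 1 to compound 3 (0.96 log units; beyond the scatter) both leave 2-nitrophenyl and start from the limit of > 199000 nM in this assay, at which 1 of the 3 values shown sits, so they offer little guidance here. The closer guide is a 1.5-fold higher number from compound 2 to compound 3 (0.18 log units; within the scatter), an exchange of one substituted phenyl for another. The move a 1.2-fold lower number from compound 3 to compound 4 (0.08 log units; within the scatter) is therefore expected to stay within the scatter, with no clear direction. For compound 4 the estimated value is 18000 nM, with an expected range of 9000 nM to 40000 nM.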

Compound 4, half-maximal cytotoxic concentration: 22000 nM
The estimate for compound 4 lay 1.2-fold (0.09 log units) below the measured number; the measured number falls inside the stated range.
By their numbers in this assay, from the lowest: compounds 2, 3 and 4 (each within the scatter of the next). At a limit, above all of these: compound 1.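

In this assay, 4-(trifluoromethyl)phenyl and 3-(trifluoromethyl)phenyl on the amide-type nitrogen cannot be told apart: a 1.0-fold higher number from compound 3 to compound 4 (0.00 log units; within the scatter). Trifluoromethyl in place of chloro on an aromatic carbon also stays within the scatter: a 1.5-fold higher number from compound 2 to compound 4 (0.18 log units; within the scatter). Against 2-nitrophenyl the new compound repeats the earlier gap, an at least 9.0-fold lower number from compound 1 to compound 4 (0.95 log units; beyond the scatter), a step that gives only a bound on its size: the limit of > 199000 nM in this assay, at which 1 of the 4 values shown sits.

Still open, as far as these compounds go, is whether the nitro group itself or its place on the ring sets compound 1 apart. Also open, from the compounds shown here alone, is whether a carboxylic acid or an amine on the phenyl would leave the number at this level.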